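Dichlorophenyl to phenyl: expecting a large loss

This account rests on a few compounds, and the source may have more. Where it says the series, first, only, none or still open, it means among the compounds named here.

Measured compounds:
compound 1 `NC1=NC2(CCSCC2)N(OCCCOc2cccc(Cl)c2Cl)C(N)=N1` gives 1 nM
compound 2 `NC1=NC2(CCOCC2)N(OCCCOc2cccc(Cl)c2Cl)C(N)=N1` gives 100 nM
compound 3 `NC1=NC2(CCSCC2)N(OCCCOc2ccc(Cl)cc2)C(N)=N1` gives 580 nM

These three share a core, and all were tested in a functional assay on A549 cells (Homo sapiens) for antiproliferative activity, read by MTT assay, with a stated time of 72 h; on this read-out lower numbers stand for stronger inhibition and higher numbers for weaker inhibition. Compound 2 stands second highest of the three numbers: its nearest neighbour is compound 3, whose value lies beyond the scatter above it, and its furthest is compound 1, whose value lies far below it.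

The unmeasured compound 4 `NC1=NC2(CCOCC2)N(OCCCOc2ccccc2)C(N)=N1` differs from compound 2 in one place: phenyl in place of 2,3-dichlorophenyl on an oxygen on a saturated carbon. Going by the values given here, one measured step bears directly on the aryl part: a 580-fold higher number from compound 1 to compound 3 (2.76 log units; beyond the scatter). That step removed one chlorine and moved the other, and the number rose sharply. Compound 4 removes both chlorines, so the expectation in this assay is a step of at least that size in the same direction, from compound 2 to compound 4, because a 580-fold higher number from compound 1 to compound 3 (2.76 log units; beyond the scatter) already points that way. The expected step is a 200-fold higher number from compound 2 to compound 4 (2.30 log units; beyond the scatter). Compound 4 is therefore expected to give about 20000 nM, within a range from 3000 nM to 100000 nM.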

Compound 4, half-maximal inhibitory concentration: 1080 nM
Beside the measured number, compound 4's estimate is 19-fold (1.27 log units) above it, outside the stated range (below it).
By their numbers in this assay, from the lowest: compound 1; then compound 2; then compounds 3 and 4 (each within the scatter of the next).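

In this assay the exchange of 2,3-dichlorophenyl for phenyl on an oxygen on a saturated carbon gives an 11-fold higher number from compound 2 to compound 4 (1.03 log units; beyond the scatter) and counts as large, so on the core of compound 2 the two chlorines alone carry a large part of the activity. The earlier step of a 580-fold higher number from compound 1 to compound 3 (2.76 log units; beyond the scatter) belonged to another core and ended in 4-chlorophenyl, so a large rise now appears on both cores, though the two changes differ and their sizes cannot be set against each other. Nothing measured here accounts for the size of this step.

From the compounds shown here alone, whether phenyl would cost as much on the core of compound 1 stays open. So does whether a naphthyl, a pyridyl or a methoxyphenyl group could stand in place of 2,3-dichlorophenyl and keep the number of compound 2.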